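This account rests on a few compounds, and the source may have more. Where it says the series, first, only, none or still open, it means among the compounds named here.

Series notes. Three members have so far been run in an ADME assay on Raji cells (Homo sapiens) for cytotoxicity, read by CellTiter-Glo and resazurin assay, with a stated time of 72 h; on this read-out lower numbers stand for an effect already at smaller amounts and higher numbers for an effect only at larger amounts of compound. Compound 1 `CC(C)N(Cc1cccc(OCCCCCC(=O)O)c1)C(=O)c1ccc(-c2ccco2)cc1` returns only a limit of the assay, > 26000 nM, and not a number. Compound 2 `CC(C)N(Cc1cccc(OCCCCCC(=O)O)c1)C(=O)c1ccc(-c2cccc(OCc3ccccc3)c2)cc1` likewise stands at a limit, > 26000 nM. Compound 3 `CC(C)N(Cc1cccc(OCCCCCC(=O)O)c1)C(=O)c1ccc(-c2cc3ccccc3n2S(=O)(=O)c2ccccc2)cc1` also gives a limit, > 26000 nM. Nothing in the series has therefore produced a number yet, as shown by the limit of > 26000 nM in this assay, at which 3 of the 3 values shown sit, and no difference between the three can be read from limits alone. Compound 4 `CC(C)N(Cc1cccc(OCCCCCC(=O)O)c1)C(=O)c1ccc(-c2cccc(F)c2)cc1` is the next member to be run. Relative to compound 2 the change is fluoro in place of benzyloxy on an aromatic carbon. With no numbered step anywhere in the series, the expectation is that this change brings no movement beyond the scatter and that compound 4 also stays at the limit. Compound 4 is expected at 40000 nM, within a range from 15000 nM to 120000 nM. The implied a step that the limit leaves unreadable from compound 2 to compound 4 is an estimate only.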

Compound 4, half-maximal effective concentration: > 26000 nM
Compound 4 gave a limit, no number; the forecaster's own chance of this, stated with the estimate: 85%; the middle value is on the limit's open side.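

Going by these compounds alone, compound 4, like compound 1 and compound 2, gives a limit and not a number, so no step to compound 4 can be read: the limit of > 26000 nM in this assay, at which 4 of the 4 values shown sit.

In this assay the compounds shown leave open whether any member of the series returns a number rather than a limit.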